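This account rests on a few compounds, and the source may have more. Where it says the series, first, only, none or still open, it means among the compounds named here.

Measured compounds:
- compound 1, `CC1=CCC2C(CC[C@@]2(C)O)C(C)(C)C1CC[C@@H]1[C@@]2(C)CC[C@@H](O)C(C)(C)O[C@@H]2CC[C@]1(C)O`, in a functional assay on MDA-MB-231 cells (Homo sapiens) for antiproliferative activity, read by MTT assay, with a stated time of 72 h (on this read-out higher numbers stand for weaker inhibition and lower numbers for stronger inhibition), compound 1 gives a value that is a limit of the assay, > 50000 nM
- compound 2, `CC1=CC[C@H]2[C@H](CC[C@]2(C)O)C(C)(C)[C@@H]1CC[C@H]1[C@]2(C)CC[C@H](OC(=O)c3ccccc3)C(C)(C)O[C@H]2CC[C@@]1(C)O`: 16100 nM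
- compound 3, `CC1=CC[C@H]2[C@@H]1CC=C(C)[C@@H](CC[C@H]1[C@]3(C)CC[C@H](OCc4ccccc4)C(C)(C)O[C@H]3CC[C@@]1(C)O)C2(C)C`: 35700 nM

Compound 2 has the lowest of the two numbers shown; compound 3 sits above it by a gap beyond the usual scatter, and compound 1 gives only a limit (the limit of > 50000 nM in this assay, at which 1 of the 3 values shown sits).

Compound 4, `CC1=CC[C@H]2[C@H](CC[C@]2(C)O)C(C)(C)[C@@H]1CC[C@H]1[C@]2(C)CC[C@H](OC(=O)c3ccccc3C(F)(F)F)C(C)(C)O[C@H]2CC[C@@]1(C)O`, is not yet measured. It differs from compound 2 by trifluoromethyl in place of hydrogen on an aromatic carbon.

Among the measured compounds shown here, no step between measured compounds carries this change, so no direct precedent exists. In this assay a step from compound 2 to compound 4 of a 1.3-fold lower number from compound 2 to compound 4 (0.13 log units; within the scatter) is expected, within the scatter rather than beyond it. Compound 4 is therefore estimated at 12000 nM, with the expected range from 4000 nM to 40000 nM.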

Compound 4, half-maximal inhibitory concentration: 31500 nM
Beside the measured number, compound 4's estimate is 2.6-fold (0.42 log units) below it, and the stated range covers the measured number.
By their numbers in this assay, from the lowest: compounds 2, 4 and 3 (each within the scatter of the next, the first and the last beyond it). At a limit, above all of these: compound 1.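

In this assay, trifluoromethyl in place of hydrogen on this aromatic carbon, ortho to a large group, gives a 2.0-fold higher number from compound 2 to compound 4 (0.29 log units; within the scatter). Among the compounds shown here, this is the first reading of any substituent on the benzoyl ring of compound 2, and compound 4 cannot be told apart from compound 2 in this assay, so the position accepts trifluoromethyl without a change beyond the scatter. Nothing measured here bears on why the step is this size.

The compounds shown leave open how a methoxy group, an amine or a carboxylic acid on the same aromatic carbon would read.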